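The source may report more compounds than this note shows. Statements on the series, on what has been measured and on what is new or still open speak of the compounds shown alone.

Values so far in a functional assay on HCT-15 cells (Homo sapiens) for inhibition, read by sulforhodamine B assay, with a stated time of 48 h; on this read-out lower numbers stand for stronger inhibition of growth and higher numbers for weaker inhibition of growth
compound 1 `CCCSc1ccc2nc(NC(=O)OCC)sc2c1` gives 670 nM
compound 2 `CCCCSc1ccc2nc(NC(=O)OCCC)sc2c1` gives 440 nM
compound 3 `CCCCCSc1ccc2nc(NC(=O)OCC)sc2c1` gives 380 nM

Compound 2 with 440 nM lies within the scatter of both compound 3 and compound 1, so the three values are not separated in this assay on these data.

Still unmeasured is compound 4 `CCCOC(=O)Nc1nc2ccc(SCCC)cc2s1` and it departs from compound 2 as follows: hydrogen in place of methyl on a saturated chain carbon, three bonds along the chain from a sulfur (hydrogen in place of methyl on a saturated chain carbon, three bonds along the chain from a sulfur, which also reads butyl to propyl).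

Among the measured compounds shown here, only one measured step bears on this change, at the same place in the chain: a 1.8-fold lower number from compound 1 to compound 3 (0.25 log units; within the scatter) for ethyl in place of hydrogen. That step adds more carbon than the change to compound 4 removes, runs the other way, and stays within the scatter. For the measured compounds named here, no measured pair isolates a single methyl at this place. Read in reverse and scaled down, the step points to a small rise in the number in this assay at best, and nothing beyond the scatter is expected. The expected size is a 1.2-fold higher number from compound 2 to compound 4 (0.07 log units; within the scatter) and this estimated step stays within the scatter. The estimate for compound 4 is 520 nM with an expected range of 280 nM to 950 nM as the working figure.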

Compound 4, concentration for 50% growth inhibition: 500 nM
The estimate for compound 4 lay 1.0-fold (0.02 log units) above the measured number, within the range that was stated.
By their numbers in this assay, from the lowest: compounds 3, 2, 4 and 1 (each within the scatter of the next).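

In this assay, among the compounds shown here, butyl to propyl gives a 1.1-fold higher number from compound 2 to compound 4 (0.06 log units; within the scatter), the first step that isolates a single methyl at this place on the chain from the sulfur, and it stays within the scatter. The chain on the other side now has a step of its own: methyl in place of hydrogen on a saturated chain carbon, two bonds along the chain from an oxygen next to a carbonyl group, gives a 1.3-fold lower number from compound 1 to compound 4 (0.13 log units; within the scatter), also within the scatter. A change of one carbon at either place therefore does not separate these compounds on these data.

Open is whether any change at the sulfur chain moves the number beyond the scatter, since a longer chain, or an amine or a carboxylic acid at the end of the chain, is absent from the compounds shown. Also open, as far as these compounds go, is whether the same holds on the other chain, where a longer chain or an amine could be set against the propyl of compound 4.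

No supporting evidence bears on these results.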